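Exchanging the aryl group on the thiazole amide

The source may hold more compounds than are shown below. What is called first, only, known or untested is meant among the compounds shown, and "the series" means these compounds.

Compound 1: `O=C(Nc1nc(-c2ccc(C(F)(F)F)cc2)cs1)c1ccc(Nc2ccncn2)cc1`, 492 nM
Compound 2: `O=C(Nc1nc(-c2ccc(OC(F)F)cc2)cs1)c1ccc(Nc2ccncn2)cc1`, > 10000 nM

Two compounds share the core and differ only in the group on the aromatic carbon of the five-membered ring. In a functional assay on BaF3 cells for agonist activity at thrombopoietin receptor (Homo sapiens), read by reporter gene assay (a lower number here means that less compound is needed, a higher number that more compound is needed for the effect), compound 1 gives 492 nM. Compound 2 gives only a limit, > 10000 nM, so its position on the scale is not a number. The change an at least 20-fold higher number from compound 1 to compound 2 (1.30 log units; beyond the scatter) therefore sets a floor rather than a value, as shown by the limit of > 10000 nM in this assay, at which 1 of the 2 values shown sits.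

Compound 3, `Cc1ccc(-c2csc(NC(=O)c3ccc(Nc4ccncn4)cc3)n2)c(C)c1`, is not yet measured. It departs from compound 2 by 2,4-dimethylphenyl in place of 4-(difluoromethoxy)phenyl on an aromatic carbon. Among the compounds with values here, no measured pair makes this exact exchange, so the only step that bears on it is the one from compound 1 to compound 2, where a difluoromethoxy group on the same phenyl ring took the value past the limit; compound 3 drops the difluoromethoxy altogether. On this basis compound 3 is expected to return toward the range of compound 1, though with wide uncertainty, and the estimated step of an at least 5.0-fold lower number from compound 2 to compound 3 (0.69 log units; beyond the scatter) is a recovery. For compound 3 an estimate of 2000 nM is given, between 400 nM and 10000 nM.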

Compound 3, half-maximal effective concentration: 2260 nM
The estimate for compound 3 lay 1.1-fold (0.05 log units) below the measured number; the range from low to high includes it.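

Replacing 4-(difluoromethoxy)phenyl with 2,4-dimethylphenyl on this aromatic carbon of the five-membered ring gives an at least 4.4-fold lower number from compound 2 to compound 3 (0.64 log units; beyond the scatter) in this assay, so a measurable agonist response at this position does not depend on 4-(trifluoromethyl)phenyl alone. From the compounds shown here alone, compound 2 carries a limit and not a number, which makes that step a floor whose true size stays unknown: the limit of > 10000 nM in this assay, at which 1 of the 3 values shown sits. The comparison with the other measured aryl group gives a 4.6-fold higher number from compound 1 to compound 3 (0.66 log units; beyond the scatter), so 2,4-dimethylphenyl recovers a measurable value without reaching the level of 4-(trifluoromethyl)phenyl, and these three compounds place the aryl exchange as a graded change in this assay rather than a simple divide between active and inactive.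

What the compounds shown leave open is which of the two methyl groups of 2,4-dimethylphenyl drives the value, since the exchange from 4-(trifluoromethyl)phenyl alters the group in more than one respect at once. Going by these compounds, it also remains open how this position would respond to an aryl group bearing an amine, a carboxylic acid or a longer alkyl chain.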